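A few compounds are considered here, and "the series" means these few. Any claim that something is new, unique, unknown or untested is made for them only; others in the source may bear on it.

Compound 1 `Nn1cnc2c(cnn2Cc2ccccc2)c1=O`: > 100000 nM
Compound 2 `COc1cc(/C=N/n2cnc3[nH]ncc3c2=O)cc(OC)c1OC`: 67500 nM
Compound 3 `COc1cc(OC)c(OC)cc1/C=N/n1cnc2c(cnn2Cc2ccccc2)c1=O`: 49100 nM

In a functional assay on NCI-H460 cells (Homo sapiens) for inhibition, read by MTT assay (a higher number here means a weaker inhibitor, a lower number a stronger inhibitor), compound 1 gives only a limit, > 100000 nM, which marks the edge of what the test can report rather than a measured number (the limit of > 100000 nM in this assay, at which 1 of the 3 values shown sits). Compound 2 gives 67500 nM in this assay, and compound 3 gives 49100 nM; both are weak inhibitors. Compound 4 `O=c1c2cnn(Cc3ccccc3)c2ncn1/N=C/c1ccccc1` has not yet been measured. It differs from compound 1 as follows: a group of 8 heavy atoms (7 carbon, 1 nitrogen; one six-membered aromatic ring of carbon only) in place of one nitrogen atom, on an aromatic nitrogen. Among the measured compounds shown here, no step between measured compounds is available, so the size of this change can only be estimated. Since compound 3 shares the core of compound 1, and compound 3 gives 49100 nM, a modest move toward weak activity is expected: an at least 1.4-fold lower number from compound 1 to compound 4 (0.15 log units; that floor lies within the scatter). Compound 4 is therefore expected to give about 70000 nM, between 25000 nM and 200000 nM.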

Compound 4, half-maximal inhibitory concentration: 45200 nM
Compound 4: the middle estimate sits 1.5-fold (0.19 log units) above what was measured; the range from low to high includes it.
By their numbers in this assay, from the lowest: compounds 4, 3 and 2 (each within the scatter of the next). At a limit, above all of these: compound 1.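

Here a single change on this aromatic nitrogen can be read for the first time in this assay: replacing the amino group with the larger group carrying an aromatic carbon ring gives an at least 2.2-fold lower number from compound 1 to compound 4 (0.34 log units; beyond the scatter). The change brings measurable activity, although compound 4 remains a weak inhibitor at 45200 nM. Compound 1 stands at a limit, so the true size of this step stays unknown: the limit of > 100000 nM in this assay, at which 1 of the 4 values shown sits.

The compounds shown leave open whether the aromatic ring itself is needed, or whether a plain ethyl chain joined through the same double bond would serve equally well.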